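A new aryl group on compound 3

The source may hold more compounds than are shown below. What is called first, only, known or untested is meant among the compounds shown, and "the series" means these compounds.

Measured so far in a toxicity assay on PC-12 cells (Rattus norvegicus) for cytotoxicity, read by MTT assay; a higher number here means a weaker inhibitor, a lower number a stronger inhibitor:
- Compound 1 `Oc1cc(C(F)(F)F)ccc1-c1nc(-c2ccccc2O)n(-c2ccc(Br)cc2)n1` gives 66800 nM
- Compound 2 `Oc1cc(C(F)(F)F)ccc1-c1nc(-c2ccccc2O)n(-c2ccc(I)cc2)n1` gives 73300 nM
- Compound 3 `Oc1cc(C(F)(F)F)ccc1-c1nc(-c2ccccc2O)n(-c2cccc(C(F)(F)F)c2)n1` gives 49700 nM

These three values sit within the scatter of one another, so compound 3 cannot be set apart from the others. The account shows a 1.3-fold lower number from compound 1 to compound 3 (0.13 log units; within the scatter) and a 1.5-fold lower number from compound 2 to compound 3 (0.17 log units; within the scatter), and both steps stay within the scatter.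

The next compound is compound 4 `Cc1cc(C)cc(-n2nc(-c3ccc(C(F)(F)F)cc3O)nc2-c2ccccc2O)c1`, which carries 3,5-dimethylphenyl in place of 3-(trifluoromethyl)phenyl on an aromatic nitrogen. The two steps into compound 3 bear most directly on this change, since each replaces the group on that same nitrogen. The halogen exchange also bears on it, with a 1.1-fold higher number from compound 1 to compound 2 (0.04 log units; within the scatter), again within the scatter. Among the compounds with values here, no measured compound has methyl groups on this aryl group, so the evidence is indirect. Even so, no change at this place has yet moved the number beyond the scatter, and none is expected here in this assay, in either direction.

The estimate means an expected 1.2-fold higher number from compound 3 to compound 4 (0.08 log units; within the scatter). For compound 4 the estimated value is 60000 nM, with an expected range from 30000 nM to 115000 nM.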

Compound 4, half-maximal inhibitory concentration: 263000 nM
The estimate for compound 4 lay 4.4-fold (0.64 log units) below the measured number; the measured number lies above the stated range.
By their numbers in this assay, from the lowest: compounds 3, 1 and 2 (each within the scatter of the next); then compound 4.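

In this assay the group on the aromatic nitrogen proves able to move the number beyond the scatter: the change to 3,5-dimethylphenyl gives a 5.3-fold higher number from compound 3 to compound 4 (0.72 log units; beyond the scatter) and also a 3.6-fold higher number from compound 2 to compound 4 (0.55 log units; beyond the scatter) and a 3.9-fold higher number from compound 1 to compound 4 (0.60 log units; beyond the scatter) in the same direction. The earlier compounds shown here suggested that this position made little difference, yet that held only among the 4-bromophenyl, 4-iodophenyl and 3-(trifluoromethyl)phenyl groups, and compound 4 now stands as the weakest inhibitor of the four, with all three of its steps beyond the scatter. Nothing available explains why 3,5-dimethylphenyl stands apart from the other three groups.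

The compounds shown leave open whether the higher number goes with methyl groups as such or with their arrangement in 3,5-dimethylphenyl, a question that a 3-methylphenyl or a 3,5-dichlorophenyl group on the same nitrogen could help to separate. They also leave open whether the step from compound 3 to compound 4 would hold with a methoxy group in place of the hydroxy group on the 2-hydroxyphenyl ring.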